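Working notes: from compound 3 to compound 4

The source may hold more compounds than are shown below. What is called first, only, known or untested is meant among the compounds shown, and "the series" means these compounds.

Measured in a functional assay on VCaP cells (Homo sapiens) for antiproliferative activity, read by CCK-8 assay, with a stated time of 6 days; on this read-out lower numbers stand for stronger inhibition and higher numbers for weaker inhibition:
- compound 1 `N#Cc1ccc(N2CCc3cc(-c4cncnc4)ccc32)cc1C(F)(F)F`: "not determined" (no result reported)
- compound 2 `N#Cc1ccc(N2CCCc3c(-c4ccncc4)cccc32)cc1C(F)(F)F`: > 30000 nM (a limit)
- compound 3 `CCN(c1ccc(C#N)c(Cl)c1)c1cc(-c2ccco2)ccc1C`: > 30000 nM (a limit)

Compound 3 stands at the limit of > 30000 nM in this assay, at which 2 of the 3 values shown sit. Compound 4 `CCN(c1ccc(C#N)c(Cl)c1)c1cc(-c2ccc(F)nc2)ccc1C` differs from it on an aromatic carbon para to a methyl group, with 6-fluoropyridin-3-yl in place of furan-2-yl on an aromatic carbon. Among the compounds with values here, no measured pair in this assay shows the effect of this swap, so the expectation rests on the limit alone. The estimated step is small and towards stronger inhibition: an at least 2.0-fold lower number from compound 3 to compound 4 (0.30 log units; that floor lies within the scatter). Compound 4 is expected near 15000 nM, with an estimated range of 4000 nM to 30000 nM, and a result reported only as a limit would not be surprising.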

Compound 4, half-maximal inhibitory concentration: > 30000 nM
Compound 4: only a limit was reported; the forecaster's own chance of this, stated with the estimate: 60%; at least 2.0-fold (0.30 log units) between middle value and limit.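

Within the data shown here, compound 3 and compound 4 both stand only as limits in this assay, and no step between them can be read. The compounds shown leave open whether 6-fluoropyridin-3-yl and furan-2-yl differ at all on the shared core.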